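The compounds below may be only part of what the source reports. "The series", "measured", "known", "first", "only" and "open" are said of these compounds alone.

Measured compounds:
compound 1, `Oc1cccc(-c2cc(-c3ccccc3F)cc(-c3ccccc3O)n2)c1`, 8470 nM
compound 2, `Oc1cccc(-c2cc(-c3ccccc3F)cc(-c3cccc(O)c3)n2)c1`, 5300 nM
compound 3, `Oc1ccccc1-c1cc(-c2ccccc2C(F)(F)F)cc(-c2ccccc2O)n1`, 3970 nM

In a functional assay on HCT-15 cells (Homo sapiens) for inhibition (a lower number here means a stronger inhibitor, a higher number a weaker inhibitor), compound 1 gives 8470 nM. Compound 2 gives 5300 nM, and the step of a 1.6-fold lower number from compound 1 to compound 2 (0.20 log units; within the scatter) (3-hydroxyphenyl in place of 2-hydroxyphenyl on an aromatic carbon) stays within the scatter. Compound 3 gives 3970 nM; the difference between its core and that of compound 1 is not broken down here. Compound 4, `Oc1cccc(-c2cc(-c3ccccc3C(F)(F)F)cc(-c3ccccc3O)n2)c1`, is the same kind of change on the core of compound 3 (3-hydroxyphenyl in place of 2-hydroxyphenyl on an aromatic carbon): there the place lies meta to a 2-(trifluoromethyl)phenyl group and meta to a 2-hydroxyphenyl group, whereas in compound 1 it lies meta to a 2-fluorophenyl group and meta to a 3-hydroxyphenyl group. Because the earlier step of a 1.6-fold lower number from compound 1 to compound 2 (0.20 log units; within the scatter) was small, a similarly small step a 1.4-fold lower number from compound 3 to compound 4 (0.15 log units; within the scatter) is expected in this assay. Compound 4 is therefore estimated at 2800 nM, between 1200 nM and 6500 nM.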

Compound 4, half-maximal inhibitory concentration: 9010 nM
Compound 4: the middle estimate sits 3.2-fold (0.51 log units) below what was measured; measured number outside the range, above it.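

In this assay, 3-hydroxyphenyl in place of 2-hydroxyphenyl does not give the same result on the two cores: the same change on two cores in this assay, a 1.6-fold lower number (0.20 log units; within the scatter) from compound 1 to compound 2 and a 2.3-fold higher number (0.36 log units; beyond the scatter) from compound 3 to compound 4, 3.6-fold (0.56 log units) apart, beyond the scatter of two such steps On the core of compound 3 the change gives a 2.3-fold higher number from compound 3 to compound 4 (0.36 log units; beyond the scatter), while trifluoromethyl in place of fluoro gives a 1.1-fold higher number from compound 1 to compound 4 (0.03 log units; within the scatter). Going by these compounds alone, with only one pair on each core, these results show that the outcome of the change depends on the core here, but not why, nor how it would read on a further core.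

The compounds shown leave open how a methoxy group or an amine in place of the hydroxyl would read in this assay. They also leave open whether chloro or methyl in place of fluoro would behave like trifluoromethyl.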